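A Bromophenyl Swap on a Shared Core

A few compounds are considered here, and "the series" means these few. Any claim that something is new, unique, unknown or untested is made for them only; others in the source may bear on it.

Among the measured compounds shown here, in a functional assay on MCF7 cells (Homo sapiens) for cytotoxicity, read by MTT assay, with a stated time of 72 h (on this read-out lower numbers stand for stronger inhibition and higher numbers for weaker inhibition), compound 1 (`COc1ccc(OC)c(/C=C/C(=O)Nc2cc3c(Nc4ccc(F)c(Cl)c4)ncnc3cc2OC)c1`) gives 34300 nM and sets the only point of comparison for compound 2 (`O=C(/C=C/c1cc(Br)c(O)c(Br)c1)Nc1cc2c(Nc3ccc(F)c(Cl)c3)ncnc2cc1O[C@H]1CCOC1`). Compound 2 stands at 30600 nM within the scatter of compound 1, so the two cannot be ordered. Compound 3 (`O=C(/C=C/c1ccc(Br)cc1)Nc1cc2c(Nc3ccc(F)c(Cl)c3)ncnc2cc1O[C@H]1CCOC1`) has not yet been measured. It differs from compound 2 in one place (4-bromophenyl in place of 3,5-dibromo-4-hydroxyphenyl on a double-bonded chain carbon bound to a double-bonded chain carbon), with 4-bromophenyl in place of 3,5-dibromo-4-hydroxyphenyl on a double-bonded chain carbon bound to a double-bonded chain carbon. For the measured compounds named here, no measured step shows what such a change does in this assay and the two known values lie close together, so no shift beyond the scatter is expected in either direction. The expected step (a 1.2-fold lower number from compound 2 to compound 3 (0.09 log units; within the scatter)) is therefore small. For compound 3 the estimate is 25000 nM with an expected span from 9000 nM to 60000 nM as its range.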

Compound 3, half-maximal inhibitory concentration: 32400 nM
Compound 3: the middle estimate sits 1.3-fold (0.11 log units) below what was measured; low and high end bracket the measured number.
By their numbers in this assay, from the lowest: compounds 2, 3 and 1 (each within the scatter of the next).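

In this assay, among the compounds shown here, 4-bromophenyl in place of 3,5-dibromo-4-hydroxyphenyl on a double-bonded chain carbon bound to a double-bonded chain carbon gives a 1.1-fold higher number from compound 2 to compound 3 (0.02 log units; within the scatter), the first step that can be read at this position, and it does not separate the two compounds. The hydrogen-bond donor and acceptor counted on the group that leaves are absent from the group that enters, yet the read-out offers no sign that this exchange matters here. Nothing at hand bears on why this is so.

The bromine atoms and the hydroxyl leave in one step, so the shown compounds cannot tell their shares apart, if either has one. As far as these compounds go, it also remains open whether an amine or a carboxylic acid on that phenyl ring would give a step beyond the scatter.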